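Compound 3 to compound 4: three limits, one open step

The compounds below may be only part of what the source reports. "The series", "measured", "known", "first", "only" and "open" are said of these compounds alone.

Compound 1 `COc1ccc(-c2cnc(NC(=O)C3CCNCC3)n2C)cc1`: > 100000 nM
Compound 2 `COc1ccc(-c2cnc(NC(=O)c3cnc[nH]3)n2C)cc1`: > 100000 nM
Compound 3 `COc1ccc(-c2cnc(NC(=O)c3ccno3)n2C)cc1`: > 100000 nM

These readings come from a toxicity assay on THP-1 cells (Homo sapiens) for inhibition (a lower number here means that less compound is tolerated, a higher number that more compound is tolerated), and each is a limit of the assay rather than a number. Compound 3 stands at > 100000 nM, which is such a limit. Within the data shown here, it has company: the series so far shows (the limit of > 100000 nM in this assay, at which 3 of the 3 values shown sit).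

Compound 4 `COc1ccc(-c2cnc(NC(=O)c3ccc(O)cc3)n2C)cc1` has not yet been measured. Its difference from compound 3 is 4-hydroxyphenyl in place of 1,2-oxazol-5-yl on a carbonyl carbon. In words, 4-hydroxyphenyl takes the place of 1,2-oxazol-5-yl on a carbonyl carbon, and the rest of the structure stays the same.

Among the measured compounds shown here, three measured steps bear on this change, as each is an exchange on that same carbonyl carbon. They are a step that the two limits leave unreadable from compound 1 to compound 2, a step that the two limits leave unreadable from compound 1 to compound 3 and a step that the two limits leave unreadable from compound 2 to compound 3. None has a readable size, so they offer no measured change to carry over, and 4-hydroxyphenyl has not been tested among them. No direction can therefore be expected in this assay, and no step beyond the scatter is foreseen. The expected step, an estimate only, is a number no higher from compound 3 to compound 4 (the limit leaves the size open). For compound 4 the estimated value is 100000 nM, with an expected range from 40000 nM to 200000 nM.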

Compound 4, half-maximal cytotoxic concentration: > 100000 nM
Compound 4 gave a limit, no number; the forecaster's own chance of this, stated with the estimate: 75%; the middle value sits exactly at the limit.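

In this assay compound 4 gives > 100000 nM, which is a limit of the assay and not a number. Its steps from compound 1, compound 2 and compound 3 therefore cannot be read. The series now stands thus: the limit of > 100000 nM in this assay, at which 4 of the 4 values shown sit. The compounds shown leave open whether any exchange on the carbonyl carbon changes toxicity in this assay.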